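This account rests on a few compounds, and the source may have more. Where it says the series, first, only, none or still open, it means among the compounds named here.

Measured compounds:
- Compound 1, `C=C1C(=O)OC(C)CC1c1ccc(Br)cc1`: 4510 nM
- Compound 2, `C=C1C(=O)O[C@H](C)[C@@H]1c1ccc([N+](=O)[O-])cc1`: 3770 nM

In a functional assay on NALM-6 cells (Homo sapiens) for cytotoxicity, read by MTT assay, with a stated time of 48 h (a higher number here means a weaker inhibitor, a lower number a stronger inhibitor), compound 2 gives 3770 nM, the lowest of the two numbers shown. Its nearest neighbour is compound 1, which in this assay gives 4510 nM; the gap between the two is within the usual scatter, so neither can be called stronger or weaker than the other.

Compound 3, `C=C1C(=O)O[C@H](C)[C@@H]1c1ccc(Br)cc1`, has not yet been measured. It differs from compound 2 in one place: bromo in place of nitro on an aromatic carbon. Compound 3 also has the same atoms and connections as compound 1, now drawn with defined stereochemistry. Within the data shown here, no measured step covers this change, but with compound 1 and compound 2 sitting so close to each other, no step beyond the scatter is expected, in either direction. The estimate for compound 3 in this assay is 4000 nM, between 1500 nM and 12000 nM, which amounts to an expected step of a 1.1-fold higher number from compound 2 to compound 3 (0.03 log units; within the scatter).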

Compound 3, half-maximal inhibitory concentration: 4250 nM
The estimate for compound 3 lay 1.1-fold (0.03 log units) below the measured number; low and high end bracket the measured number.
By their numbers in this assay, from the lowest: compounds 2, 3 and 1 (each within the scatter of the next).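

In this assay bromo in place of nitro on an aromatic carbon gives a 1.1-fold higher number from compound 2 to compound 3 (0.05 log units; within the scatter) and that step lies within the scatter. Among these compounds, this is the first direct comparison at this place, para to a group of 8 heavy atoms, and it shows that the read-out does not separate these two groups, even though nitro brings 3 heavy atoms and 2 hydrogen-bond acceptors while bromo brings 1 heavy atom and no acceptor. Nothing in the data available here accounts for this match.

Still open, from the compounds shown here alone, is whether an amine or a carboxylic acid on this same aromatic carbon would shift the number beyond the scatter. A longer chain there, such as a butyl group, is equally untested by the compounds shown, so the tolerance of this place remains unknown.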